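A smaller ring on the sulfonyl sulfur

The source may report more compounds than this note shows. Statements on the series, on what has been measured and on what is new or still open speak of the compounds shown alone.

In an ADME assay on HepG2 2.2.15 cells (Homo sapiens) for cytotoxicity, read by luminescence, with a stated time of 3 days (on this read-out lower numbers stand for higher toxicity in this test and higher numbers for lower toxicity in this test), compound 1 `O=C(Nc1ccc(F)c(Cl)c1)c1ccc(F)c(S(=O)(=O)N2C[C@H](O)CC[C@H](O)C2)c1` gives 25500 nM. Compound 2 `O=C(Nc1ccc(F)c(Cl)c1)c1ccc(F)c(S(=O)(=O)N2CCCCCC(O)C2)c1` gives 11000 nM, and compound 3 `O=C(Nc1ccc(F)c(Cl)c1)c1ccc(F)c(S(=O)(=O)N2CCCCCCC2O)c1` gives 7000 nM. Compound 3 shares the low end of this small set: a 1.6-fold lower number from compound 2 to compound 3 (0.20 log units; within the scatter) stays within the scatter, while a 3.6-fold lower number from compound 1 to compound 3 (0.56 log units; beyond the scatter) goes beyond it.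

Compound 4 `CC1(O)CCCN(S(=O)(=O)c2cc(C(=O)Nc3ccc(F)c(Cl)c3)ccc2F)CC1` has the same atoms as compound 3, joined differently: a group of 9 heavy atoms (7 carbon, 1 nitrogen, 1 oxygen; one seven-membered non-aromatic ring with 1 hetero atom) in place of a group of 9 heavy atoms (7 carbon, 1 nitrogen, 1 oxygen; one eight-membered non-aromatic ring with 1 hetero atom), on a sulfonyl sulfur. The eight-membered ring on the sulfonyl sulfur gives way to 4-hydroxy-4-methylazepan-1-yl, a seven-membered ring.

The nearest guides run the opposite way, with an eight-membered ring replacing a seven-membered one. These are a 2.3-fold lower number from compound 1 to compound 2 (0.37 log units; beyond the scatter) and a 3.6-fold lower number from compound 1 to compound 3 (0.56 log units; beyond the scatter), both modest, although each also changes the oxygen count and so bears only partly on this case. A small rise in the number is therefore expected, and the estimated step is a 2.0-fold higher number from compound 3 to compound 4 (0.30 log units; within the scatter). For compound 4 the estimate in this assay is 14000 nM, with an expected range from 6000 nM to 32000 nM.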

Compound 4, half-maximal cytotoxic concentration: 11000 nM
Beside the measured number, compound 4's estimate is 1.3-fold (0.10 log units) above it; low and high end bracket the measured number.
By their numbers in this assay, from the lowest: compounds 3, 2 and 4 (each within the scatter of the next); then compound 1.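

In this assay, the step to 4-hydroxy-4-methylazepan-1-yl does not separate compound 4 from the compounds with eight-membered rings: a 1.6-fold higher number from compound 3 to compound 4 (0.20 log units; within the scatter) and no change at the digits printed from compound 2 to compound 4 (within the scatter) both stay within the scatter. Compound 1 also carries a seven-membered ring, yet a 2.3-fold lower number from compound 1 to compound 4 (0.37 log units; beyond the scatter) lies beyond the scatter, so among these compounds a shared ring size does not bring a shared number, and the group's other features also go with the read-out. Nothing shown here explains this difference in cytotoxicity.

On these data alone, the step from compound 1 to compound 4 swaps two hydroxy-bearing ring positions for one hydroxy and one methyl group at once, so the share of each change remains open. Also open, as far as these compounds go, is how an amine in place of the hydroxy group on the seven-membered ring would read.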